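The compounds below may be only part of what the source reports. "The series", "measured", "known", "first", "only" and "open" are said of these compounds alone.

Compound 1 has the structure `S=C(Nc1ccccc1)OCCc1ccccn1`. In an ADME assay on MT4 cells (Homo sapiens) for cytotoxicity, read by MTT assay (a higher number here means that more compound is tolerated, a lower number that less compound is tolerated), compound 1 gives > 100000 nM, which is a limit of the assay rather than a number, so compound 1 sits at the limit of > 100000 nM in this assay, at which 1 of the 2 values shown sits. Going by the values given here, the only measured neighbour is compound 2, `Cc1ccc(NC(=S)OCCc2ccccn2)cc1`, which differs from compound 1 by methyl in place of hydrogen on an aromatic carbon; in this assay compound 2 gives 75000 nM. Among the compounds with values here, the single measured step, an at least 1.3-fold lower number from compound 1 to compound 2 (0.12 log units; that floor lies within the scatter), lies within the scatter, so the one comparable change left the tolerated concentration essentially where it was. Compound 3, `COc1ccc(NC(=S)OCCc2ccccn2)cc1`, differs from compound 1 by methoxy in place of hydrogen on an aromatic carbon. With no step beyond the scatter to build on, the expectation for compound 3 in this assay is a value close to that of its neighbours, estimated at 80000 nM with a range from 40000 nM to 160000 nM. This estimate corresponds to an expected step of an at least 1.2-fold lower number from compound 1 to compound 3 (0.09 log units; that floor lies within the scatter), which is within the scatter.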

Compound 3, half-maximal cytotoxic concentration: 48000 nM
Beside the measured number, compound 3's estimate is 1.7-fold (0.22 log units) above it; the measured number falls inside the stated range.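

Going by these compounds alone, at the aromatic carbon para to a large group, methoxy in place of hydrogen gives the first step beyond the scatter in this assay: an at least 2.0-fold lower number from compound 1 to compound 3 (0.31 log units; beyond the scatter). This step is only a floor, because compound 1 stands at a limit of the assay and not at a number: the limit of > 100000 nM in this assay, at which 1 of the 3 values shown sits. Methoxy and methyl at this carbon do not separate, with a 1.6-fold lower number from compound 2 to compound 3 (0.19 log units; within the scatter), so the data set methoxy apart from hydrogen but not from methyl.

From the compounds shown here alone, the full size of the step from hydrogen to methoxy remains open, since only its floor is known. Also open, going by these compounds, is how the tolerated concentration would respond to other groups at this carbon, such as an amine, a carboxylic acid or a longer alkoxy chain.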